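A few compounds are considered here, and "the series" means these few. Any claim that something is new, unique, unknown or untested is made for them only; others in the source may bear on it.

Working notes on the hydrazone series

Three compounds have been run in a functional assay on cells (Mus musculus) for cytotoxicity, read by MTT assay, with a stated time of 24 h, tested at 1 uM; on this read-out lower numbers stand for a weaker effect and higher numbers for a stronger effect at the one concentration tested. Compound 1 `COc1cc(/C=N/NC(=O)OCc2ccccc2)cc(OC)c1O` gives 45% in this assay. Compound 2 `COc1cc(/C=N/Nc2nc3ccccc3s2)cc(OC)c1O` gives 39%, which sits within the scatter of compound 1. Compound 3 `COc1cc(/C=N/Nc2nc3ccccc3s2)cc(OC)c1OC` gives 4%, well apart from both.

Compound 3 and compound 2 differ in one place, (hydrogen in place of methyl on an oxygen on an aromatic ring), and the step is a number 35 percentage points higher from compound 3 to compound 2 (beyond the scatter). Compound 1 and compound 3 share no single counted difference; the difference between the two cores is not broken down here.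

Compound 4 `COc1cc(/C=N/NC(=O)OCc2ccccc2)cc(O)c1O` is not yet measured. It differs from compound 1 by hydrogen in place of methyl on an oxygen on an aromatic ring, the same change that separates compound 3 from compound 2, at a place described in the same words. Within the data shown here, only this one precedent exists, and it is on the core of compound 3 rather than that of compound 1, so the carry-over is uncertain. A rise is expected for compound 4, estimated at a number 15 percentage points higher from compound 1 to compound 4 (beyond the scatter), smaller than the earlier step because compound 1 already stands at 45%. The expected value for compound 4 is 60%, between 38% and 82%.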

Compound 4, a percentage reported as activity, at one concentration (the size of the read-out at that concentration, not a potency): 34%
For compound 4 the middle estimate is 26 percentage points above the measured one, outside the stated range (below it).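

In this assay, methoxy to hydroxy on the core of compound 1 gives a number 11 percentage points lower from compound 1 to compound 4 (beyond the scatter), so the rise seen on the other core does not reappear here. Set side by side, the two steps differ in direction as well as in size: the same change on two cores in this assay, a number 35 percentage points higher (beyond the scatter) from compound 3 to compound 2 and a number 11 percentage points lower (beyond the scatter) from compound 1 to compound 4, 46 percentage points apart, beyond the scatter of two such steps.

Among these compounds, for this series, the outcome of this change therefore cannot be carried from one core to the other, and any estimate for a further core has no firm precedent in these two pairs. What this does not show is which structural difference between the cores goes with the reversal, whether the same split would appear on a third core, or how the steps would look at any other concentration.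

The compounds shown leave open how an ethyl group or a longer chain in place of methyl on the oxygen would behave on each core. Also open, on these data alone, is whether an amine at that place on the aromatic ring would follow either step.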